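The source may hold more compounds than are shown below. What is called first, only, known or untested is meant among the compounds shown, and "the series" means these compounds.

Measured in a functional assay on L1210 cells (Mus musculus) for antiproliferative activity, read by cell counting, with a stated time of 48 h; on this read-out higher numbers stand for weaker inhibition and lower numbers for stronger inhibition:
- compound 1 `C#C[C@@]1(O)[C@@H](CO)O[C@@H](n2cnc3c(-c4ccccc4)ncnc32)[C@@H]1O`: > 250000 nM, a limit
- compound 2 `C#C[C@@]1(O)[C@@H](CO)O[C@@H](n2cnc3c(-c4ccc(OC)cc4)ncnc32)[C@@H]1O`: > 250000 nM, a limit

Compound 2 stands at > 250000 nM, which is a limit and not a number. Within the data shown here, the only other value shown, for compound 1, is a limit too, so the series so far rests on (the limit of > 250000 nM in this assay, at which 2 of the 2 values shown sit). Among the measured compounds shown here, the one measured step, methoxy in place of hydrogen on an aromatic carbon, is a step that the two limits leave unreadable from compound 1 to compound 2, and it offers no size to carry forward.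

Compound 3 `C#C[C@@]1(O)[C@@H](CO)O[C@@H](n2cnc3c(-c4ccc(Cl)cc4)ncnc32)[C@@H]1O` has chloro in place of methoxy on an aromatic carbon, para to a large group: chloro in place of methoxy on an aromatic carbon. With no readable step behind it, no change beyond the scatter is expected in this assay, in either direction. The expected step is a number no higher from compound 2 to compound 3 (the limit leaves the size open). For compound 3 the estimate is 250000 nM, with an expected range from 100000 nM to 500000 nM, and a further limit is the likeliest report.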

Compound 3, half-maximal inhibitory concentration: 225000 nM
Compound 3: middle estimate off by 1.1-fold (0.05 log units), on the high side; low and high end bracket the measured number.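

In this assay, among these compounds, compound 3 gives 225000 nM, the first number rather than a limit, so chloro at this place, para to a large group, yields a measurable value. Chloro in place of methoxy gives an at least 1.1-fold lower number from compound 2 to compound 3 (0.04 log units; that floor lies within the scatter), and chloro in place of hydrogen gives an at least 1.1-fold lower number from compound 1 to compound 3 (0.04 log units; that floor lies within the scatter). Each step has a floor and no full size, and the series still rests largely on one limit: the limit of > 250000 nM in this assay, at which 2 of the 3 values shown sit.

Going by these compounds, it remains open whether any group at this place gives a step beyond the scatter. An amine, a carboxylic acid or a longer chain such as butoxy on the same aromatic carbon would test whether the number can move well clear of that limit.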